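Swapping Chloro for Fluoro in a Cytotoxic Compound Series

This account rests on a few compounds, and the source may have more. Where it says the series, first, only, none or still open, it means among the compounds named here.

Compound 1 `C/C(=N\NC(=S)Nc1ccccc1I)c1ccccn1`, compound 2 `CC(=NNC(=S)Nc1cccc(F)c1)c1ccccn1` and compound 3 `C/C(=N/NC(=S)Nc1ccc(Cl)cc1)c1ccccn1` share a core and each carries a halogen. In a functional assay on U-87MG ATCC cells (Homo sapiens) for cytotoxicity, read by MTT assay, with a stated time of 48 h (on this read-out higher numbers stand for weaker inhibition and lower numbers for stronger inhibition), compound 1 gives 6.1 nM, compound 2 gives 18 nM and compound 3 gives 1.7 nM. Compound 3 therefore has the lowest number of the three, clearly apart from the other two, which makes it the most potent so far.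

Compound 4 `C/C(=N/NC(=S)Nc1ccc(F)cc1)c1ccccn1` is built from compound 3 with a single change: fluoro in place of chloro on an aromatic carbon. In words, this is fluoro in place of chloro on an aromatic carbon. Among the compounds with values here, no two measured compounds differ in one place only, so the data hold no direct measure of this swap. The nearest hint is compound 2, which also carries fluoro and gives 18 nM, although it is not a direct match for compound 4. Compound 3 also starts from the lowest value, 1.7 nM, so a new compound seems more likely to land above it than below it.

A modest move toward weaker inhibition is therefore expected in this assay, with an estimated 2.4-fold higher number from compound 3 to compound 4 (0.37 log units; beyond the scatter). Compound 4 is expected to give about 4 nM, within an estimated range of 1.2 nM to 14 nM.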

Compound 4, half-maximal inhibitory concentration: 10 nM
The estimate for compound 4 lay 2.5-fold (0.40 log units) below the measured number; measured number inside the range.
By their numbers in this assay, from the lowest: compound 3; then compounds 1, 4 and 2 (each within the scatter of the next, the first and the last beyond it).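

On this aromatic carbon, para to a large group, the data now hold a direct reading of the swap: in this assay, fluoro in place of chloro gives a 5.9-fold higher number from compound 3 to compound 4 (0.77 log units; beyond the scatter), a modest step but one beyond the usual scatter, so the two halogens are not interchangeable here. The change is small on paper, with one heavy atom leaving, one entering, no ring involved, no hydrogen-bond donors or acceptors counted on either group and no net charge, yet that single exchange is enough to move the number measurably. Nothing available on the properties of these compounds accounts for the size or direction of this step.

The compounds shown leave open where other groups at this same place, such as bromo, methoxy or an amine, would fall relative to chloro and fluoro, and two halogens alone do not make a trend. Within the data shown here, it also remains open whether the same swap elsewhere on the ring would give a step of similar size, as this single pair is the only direct reading of it.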